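The source may report more compounds than this note shows. Statements on the series, on what has been measured and on what is new or still open speak of the compounds shown alone.

Measured in a functional assay on K562 cells (Homo sapiens) for cytotoxicity, read by MTT assay, with a stated time of 72 h; a lower number here means a stronger inhibitor, a higher number a weaker inhibitor:
- Compound 1 `O=C(/C=C/c1ccc(Cl)cc1Cl)c1cc(Cl)ccc1O`: 65600 nM
- Compound 2 `O=C(/C=C/c1cccc(Cl)c1)c1cc(Cl)ccc1O`: 41100 nM

Only these two compounds have been measured so far, and they lie within the usual scatter of each other. Compound 1, at 65600 nM, therefore cannot be told apart from compound 2, at 41100 nM, and both values sit in the same range.

The next compound to be read is compound 3 `O=C(/C=C/c1ccccc1Cl)c1cc(Cl)ccc1O`, which is related to compound 1 by a single change: hydrogen in place of chloro on an aromatic carbon. Hydrogen stands in place of chloro on an aromatic carbon, and the rest of the structure stays the same. For the measured compounds named here, no measured pair in this small set shows what this exchange does on its own, so any expectation rests on thin evidence. The two values in hand, compound 1 at 65600 nM and compound 2 at 41100 nM, give no sign of a large shift, so no step beyond the scatter is expected in this assay. The expected change is a 1.3-fold lower number from compound 1 to compound 3 (0.12 log units; within the scatter). Compound 3 is estimated at 50000 nM, with an expected range of 22000 nM to 110000 nM.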

Compound 3, half-maximal inhibitory concentration: 41800 nM
Compound 3: middle estimate off by 1.2-fold (0.08 log units), on the high side, and the stated range covers the measured number.
By their numbers in this assay, from the lowest: compounds 2, 3 and 1 (each within the scatter of the next).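

In this assay, for the compounds shown here, putting hydrogen in place of the chloro group that stands para to a large group and meta to a chloro group gives a 1.6-fold lower number from compound 1 to compound 3 (0.20 log units; within the scatter), the first direct reading of this exchange on its own. Going by these compounds alone, on the core of compound 1, this chloro group can therefore give way to hydrogen with no difference that this read-out can resolve, so the single exchange neither strengthens nor weakens the compound measurably. Nothing in hand explains this result or shows what the chloro group does at this place on the ring.

Within the data shown here, it remains open whether another group on the same aromatic carbon, such as an amine, a methoxy group or a carboxylic acid, would give a step beyond the scatter, since chloro and hydrogen are the only two groups compared there as a single exchange. Also open, on these data alone, is whether the same exchange would read the same way at the chloro group that compound 3 keeps on this ring, as a single step from compound 3 to the compound with hydrogen there would be needed to tell.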